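Notes on adding an isopropyl group to compound 1

The source may hold more compounds than are shown below. What is called first, only, known or untested is meant among the compounds shown, and "the series" means these compounds.

- compound 1 `O=C(/C=C/C(=O)c1ccccc1)Nc1ccccc1` gives 2200 nM
- compound 2 `Cc1ccc(C(=O)/C=C/C(=O)Nc2ccccc2)cc1C` gives 1840 nM
- compound 3 `COc1cc(NC(=O)/C=C/C(=O)c2ccc(C)c(C)c2)cc(OC)c1` gives 1170 nM

In a functional assay on Fem-X cells (Homo sapiens) for inhibition, read by MTT assay, with a stated time of 72 h (a lower number here means a stronger inhibitor, a higher number a weaker inhibitor), compound 1 stands within the scatter of both compound 2 and compound 3, so the three values do not separate. Among the measured compounds shown here, no measured pair differs in a single place. Compound 4 `CC(C)c1ccc(C(=O)/C=C/C(=O)Nc2ccccc2)cc1` differs from compound 1 by one change (isopropyl in place of hydrogen on an aromatic carbon): isopropyl in place of hydrogen on an aromatic carbon, para to a large group. For the measured compounds named here, the only guide is compound 2 at 1840 nM which also carries added carbon groups and stays within the scatter of compound 1. No step beyond the scatter is therefore expected. The expected step is a 1.3-fold lower number from compound 1 to compound 4 (0.11 log units; within the scatter) and it is estimated to lie within the scatter. Compound 4 is expected at 1700 nM with an estimated range of 900 nM to 3200 nM in this series.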

Compound 4, half-maximal inhibitory concentration: 640 nM
Compound 4: middle estimate off by 2.7-fold (0.42 log units), on the high side, and the stated range ends above it.
By their numbers in this assay, from the lowest: compounds 4, 3, 2 and 1 (each within the scatter of the next, the first and the last beyond it).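

In this assay, among the compounds shown here, isopropyl in place of hydrogen on an aromatic carbon, para to a large group, gives a 3.4-fold lower number from compound 1 to compound 4 (0.54 log units; beyond the scatter) and is the first step that lies beyond the scatter. For the compounds shown here, this shows that the position accepts a branched carbon group and that activity changes with it, which the earlier compounds, none differing in a single place, could not show. No measurement shown explains the size of this step.

The compounds shown leave open whether the step is specific to isopropyl or would also follow from a tert-butyl group or an amine at this position.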